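Bromo to iodo swap in an aminochalcone pair

A few compounds are considered here, and "the series" means these few. Any claim that something is new, unique, unknown or untested is made for them only; others in the source may bear on it.

Measured so far in a functional assay on FM3A cells (Mus musculus) for antiproliferative activity, with a stated time of 48 h; on this read-out lower numbers stand for stronger inhibition and higher numbers for weaker inhibition:
- compound 1 `C=C(Br)C(=O)Nc1ccc(/C=C/C(=O)c2ccc(Br)cc2)cc1` gives 1100 nM
- compound 2 `C=C(Br)C(=O)Nc1ccc(/C=C/C(=O)c2ccc(I)cc2)cc1` gives 8300 nM
- compound 3 `Nc1ccc(/C=C/C(=O)c2ccc(Br)cc2)cc1` gives 120000 nM

Compound 3 stands highest of the three, and the core of compound 3 differs from that of compound 1 by hydrogen in place of (1-bromoethenyl)carbonyl on a nitrogen on an aromatic ring, a change that brought a 110-fold higher number from compound 1 to compound 3 (2.04 log units; beyond the scatter).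

The change iodo in place of bromo on an aromatic carbon made a 7.5-fold higher number from compound 1 to compound 2 (0.88 log units; beyond the scatter). Compound 4 `Nc1ccc(/C=C/C(=O)c2ccc(I)cc2)cc1` carries the same change on the core of compound 3: iodo in place of bromo on an aromatic carbon, at a place described in the same words, so it is the same change on a different core.

Among the compounds with values here, the step from compound 3 to compound 4 is expected to be a 4.2-fold higher number from compound 3 to compound 4 (0.62 log units; beyond the scatter), resting on the one earlier instance, because compound 1 gives 1100 nM and compound 2 gives 8300 nM. The number for compound 4 in this assay is thus estimated at 500000 nM, between 150000 nM and 1500000 nM.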

Compound 4, half-maximal inhibitory concentration: 110000 nM
The estimate for compound 4 lay 4.5-fold (0.66 log units) above the measured number; measured number outside the range, below it.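

In this assay the iodo for bromo swap does not carry from one core to the other; on the core of compound 3 it gives a 1.1-fold lower number from compound 3 to compound 4 (0.04 log units; within the scatter), which differs from the step on the core of compound 1: the same change on two cores in this assay, a 7.5-fold higher number (0.88 log units; beyond the scatter) from compound 1 to compound 2 and a 1.1-fold lower number (0.04 log units; within the scatter) from compound 3 to compound 4, 8.2-fold (0.92 log units) apart, beyond the scatter of two such steps

Hydrogen in place of (1-bromoethenyl)carbonyl gives a 13-fold higher number from compound 2 to compound 4 (1.12 log units; beyond the scatter), the same direction as in the bromo pair but a different size: the same change on two cores in this assay, a 110-fold higher number (2.04 log units; beyond the scatter) from compound 1 to compound 3 and a 13-fold higher number (1.12 log units; beyond the scatter) from compound 2 to compound 4, 8.2-fold (0.92 log units) apart, beyond the scatter of two such steps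

These two cores show that the swap's size depends on the core in this set, but they do not show what causes this or how the swap would read on any other core.

Still open, as far as these compounds go, is how the swap reads with an acetyl or chloroacetyl group on the nitrogen. Also open, from the compounds shown here alone, is how chloro or fluoro would read in place of bromo.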